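Fluorine and Hydroxyl on the Aniline Ring of Compound 1

A few compounds are considered here, and "the series" means these few. Any claim that something is new, unique, unknown or untested is made for them only; others in the source may bear on it.

Measured compounds:
compound 1, `Fc1ccccc1Nc1nc2nonc2nc1Nc1ccccc1`: 2200 nM
compound 2, `O=C(Nc1ccc(Nc2nc3nonc3nc2Nc2ccccc2F)cc1)C(F)(F)F`: 4100 nM

Both were tested in an assay on mitochondria from L6 cells (Rattus norvegicus) for activation, with a stated time of 90 min; a higher number here means that more compound is needed for the effect, a lower number that less compound is needed. For the measured compounds named here, compound 1 has the lower of the two numbers, but the only step measured, a 1.9-fold higher number from compound 1 to compound 2 (0.27 log units; within the scatter), is within the scatter, so the two compounds cannot be told apart on these data.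

Compound 3, `Oc1ccc(F)c(Nc2nc3nonc3nc2Nc2ccccc2F)c1`, has not been measured. It differs from compound 1 in one place: 2-fluoro-5-hydroxyphenyl in place of phenyl on a nitrogen on an aromatic ring. The ring that changes here is the same ring that carries the added group in compound 2, so the step from compound 1 to compound 2 is the one that bears on it; that step was small and within the scatter. A different group is added now, and a fluorine enters alongside the hydroxyl, but nothing measured points to a large move in either direction. The expectation is therefore a step near the scatter, if anything toward a slightly higher number, a 1.4-fold higher number from compound 1 to compound 3 (0.13 log units; within the scatter). Compound 3 is estimated at 3000 nM, with a range from 1200 nM to 8000 nM.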

Compound 3, half-maximal effective concentration: 30000 nM
Compound 3: middle estimate off by 10-fold (1.00 log units), on the low side; the whole stated range lies below it.
By their numbers in this assay, from the lowest: compounds 1 and 2 (each within the scatter of the next); then compound 3.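

In this assay the change from phenyl to 2-fluoro-5-hydroxyphenyl on the nitrogen gives a 14-fold higher number from compound 1 to compound 3 (1.13 log units; beyond the scatter) and so shows that this ring is sensitive to what it carries, with the change here moving the number well beyond ordinary assay variation. The earlier step on this ring was a 1.9-fold higher number from compound 1 to compound 2 (0.27 log units; within the scatter) and could not be told apart from that variation, so it gave no sign that a change here could matter this much; the two steps together show that a substituent on this ring may leave the number unreadably changed or raise it sharply, depending on the substituent. Nothing available explains the rise, so only its size is known and not its cause.

Fluorine and hydroxyl enter together in compound 3, so the compounds shown cannot divide the step between them, and it remains open whether one group alone accounts for most of it or whether the step needs both. On these data alone, it also remains open how the number would respond if a methoxy group or an amine stood in place of the hydroxyl.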